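Fluoro to Methyl in a Cytotoxicity Series

This account rests on a few compounds, and the source may have more. Where it says the series, first, only, none or still open, it means among the compounds named here.

Compound 1, `Cc1ccc(-c2cc(NO)c(C(=O)Nc3ccccc3)c(=O)o2)cc1`, gives > 20000 nM in an ADME assay on Huh-7 cells (Homo sapiens) for cytotoxicity, read by a luciferase reporter and WST assay, with a stated time of 3 days (a higher number here means that more compound is tolerated, a lower number that less compound is tolerated), a value that is a limit of the assay rather than a number.
Compound 2, `COC(=O)CNC(=O)c1c(NO)cc(-c2ccc(F)cc2)oc1=O`, gives > 20000 nM in this assay, again a limit of the assay.

Compound 2 therefore stands at the limit of what this assay can resolve, and the evidence on the measured set is simply (the limit of > 20000 nM in this assay, at which 2 of the 2 values shown sit). For the measured compounds named here, no step between measured compounds is recorded; the values of compound 1 and compound 2 show only that both sit at the limit.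

Compound 3, `COC(=O)CNC(=O)c1c(NO)cc(-c2ccc(C)cc2)oc1=O`, has not yet been measured. It differs from compound 2 by methyl in place of fluoro on an aromatic carbon. Going by the values given here, with no measured step to lean on, the expected size of the step in this assay is none beyond the scatter, with no particular direction. Compound 3 is expected to give about 30000 nM in this assay, within 12000 nM to 80000 nM, which means an expected step that the limit leaves unreadable from compound 2 to compound 3, most likely reported as a limit again.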

Compound 3, half-maximal cytotoxic concentration: > 20000 nM
Compound 3: only a limit was reported; the forecaster's own chance of this, stated with the estimate: 80%; the middle value is on the limit's open side.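

Compound 3 gives > 20000 nM in this assay, which is again a limit and not a number. For the compounds shown here, no step to compound 3 can be read from compound 1 or compound 2. From the compounds shown here alone, the concentration at which any of these three compounds becomes toxic to the cells remains open, as does whether methyl and fluoro differ at all.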